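A few compounds are considered here, and "the series" means these few. Any claim that something is new, unique, unknown or untested is made for them only; others in the source may bear on it.

Working notes on the series.

Compound 1 `COc1ccc(-c2cn3ccnc3c(-c3ccc4ncn(C5CCCCC5)c4c3)n2)cc1` gives 68.4% in a functional assay on SNB-19 cells (Homo sapiens) for inhibition, read by sulforhodamine B assay, with a stated time of 48 h, tested at 10 uM (a higher number here means more inhibition at the concentration tested (going by the name of the read-out), a lower number less inhibition), the highest of the three numbers measured. Compound 2 `O=Cc1ccc(-c2cn3ccnc3c(-c3ccc4ncn(C5CCCCC5)c4c3)n2)cc1` gives 14.4% and compound 3 `CC(=O)c1ccc(-c2cn3ccnc3c(-c3ccc4ncn(C5CCCCC5)c4c3)n2)cc1` gives 3.96%. The measured steps are a number 54 percentage points lower from compound 1 to compound 2 (beyond the scatter) and a number 64.4 percentage points lower from compound 1 to compound 3 (beyond the scatter), both large, and the smaller a number 10.4 percentage points lower from compound 2 to compound 3 (beyond the scatter).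

Compound 4 `Fc1ccccc1-c1cn2ccnc2c(-c2ccc3ncn(C4CCCCC4)c3c2)n1` differs from compound 1 in one place: 2-fluorophenyl in place of 4-methoxyphenyl on an aromatic carbon. For the measured compounds named here, no measured step replaces the methoxy group with fluorine or moves the group to another position of the phenyl ring; the only steps from compound 1, to compound 2 and to compound 3, put a carbonyl-bearing group in place of the methoxy group, and both lowered inhibition strongly. They show that the changes tried so far at this position gave a lower number, but a fluorine is not a carbonyl, so they bear on compound 4 only loosely. A drop beyond the scatter is expected, of uncertain size: the estimated step is a number 33.4 percentage points lower from compound 1 to compound 4 (beyond the scatter). Compound 4 is expected to give 35%, within 5% to 70%.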

Compound 4, a percentage reported as inhibition, at one concentration (the size of the read-out at that concentration, not a potency): 7.56%
For compound 4 the middle estimate is 27.4 percentage points above the measured one, within the range that was stated.
By their numbers in this assay, from the lowest: compounds 3, 4 and 2 (each within the scatter of the next, the first and the last beyond it); then compound 1.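

At this aromatic carbon of the shared core, the loss of inhibition in this assay is not confined to carbonyl-bearing groups, as 2-fluorophenyl gives a number 60.8 percentage points lower from compound 1 to compound 4 (beyond the scatter) and carries no carbonyl. Compound 4 also cannot be separated from the formyl and acetyl compounds, with a number 3.6 percentage points higher from compound 3 to compound 4 (within the scatter) and a number 6.8 percentage points lower from compound 2 to compound 4 (within the scatter), so among the four compounds only the 4-methoxyphenyl group keeps a substantial number. No measurement available here accounts for this drop.

Compound 4 changes both the substituent and its place on the phenyl ring, so the two contributions remain unresolved; 2-methoxyphenyl and 4-fluorophenyl would separate them. Also open, as far as these compounds go, is whether a 4-ethoxyphenyl, 4-hydroxyphenyl or 4-aminophenyl group would keep the inhibition seen with compound 1.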